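Moving the methoxy group on the carbamate of compound 3

The source may report more compounds than this note shows. Statements on the series, on what has been measured and on what is new or still open speak of the compounds shown alone.

Of the compounds shown here, three sharing one core have been measured in a functional assay on PANC-1 cells (Homo sapiens) for inhibition, read by MTT assay, with a stated time of 24 h, tested at 10 uM; a lower number here means less inhibition, a higher number more inhibition at the concentration tested (going by the name of the read-out). Compound 1 `CC(C)=CCC1Cc2c(O)cc(=O)n(CCCO)c2CC1(C)C`, which carries a free hydroxyl on the aromatic ring, gives 0%. Compound 2 `CCOc1cc(=O)n(CCCO)c2c1CC(CC=C(C)C)C(C)(C)C2` gives 16.6%, and compound 3 `COc1cccc(NC(=O)Oc2cc(=O)n(CCCO)c3c2CC(CC=C(C)C)C(C)(C)C3)c1` gives 0%. Among the compounds with values here, compound 3 therefore stands level with compound 1 at the digits reported, the two together forming the lowest pair of the three; its one neighbour beyond the scatter is compound 2, as a number 16.6 percentage points lower from compound 2 to compound 3 (beyond the scatter) shows. Within the data shown here, the only step that rose beyond the scatter was a number 16.6 percentage points higher from compound 1 to compound 2 (beyond the scatter), while no change at the digits printed from compound 1 to compound 3 (within the scatter) stayed flat.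

Compound 4 `COc1ccccc1NC(=O)Oc1cc(=O)n(CCCO)c2c1CC(CC=C(C)C)C(C)(C)C2` differs from compound 3 only on the carbamate side: 2-methoxyphenyl in place of 3-methoxyphenyl on an amide-type nitrogen. Among the measured compounds shown here, none of the measured steps touches the phenyl of the carbamate; every one of them concerns what sits on the ring oxygen. The nearest guide is compound 3 itself, whose carbamate left the read-out unchanged from compound 1. Compound 4 is therefore expected to stay close to compound 3, with a step of about a number 4 percentage points higher from compound 3 to compound 4 (within the scatter), within the scatter. The estimate for compound 4 is 4%, ranging from 0% to 18%.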

Compound 4, a percentage reported as inhibition, at one concentration (the size of the read-out at that concentration, not a potency): 0%
Estimate against measurement, compound 4: 4 percentage points above, within the range that was stated.
By their numbers in this assay, from the lowest: compounds 1, 3 and 4 (each within the scatter of the next); then compound 2.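

Swapping 3-methoxyphenyl for 2-methoxyphenyl on the amide-type nitrogen is the only change shown that touches the phenyl of the carbamate, and in this assay it gives no change at the digits printed from compound 3 to compound 4 (within the scatter) at this position. The second carbamate also matches the first in its relation to the other two compounds, with no change at the digits printed from compound 1 to compound 4 (within the scatter) and a number 16.6 percentage points lower from compound 2 to compound 4 (beyond the scatter) in the same assay, so both methoxy placements tested leave the two carbamates level with the free hydroxyl of compound 1 and apart from the ethyl ether of compound 2. With compound 3 at 0% and compound 4 at 0% in this read-out, the pair shows no effect of the methoxy placement, and no measurement offered here accounts for the flat result or for the gap to compound 2.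

The compounds shown leave open whether a chlorine or an amine on the phenyl of the carbamate, or an unsubstituted phenyl, would lift the reading above that of compound 1. They also leave open whether a propyl or benzyl group on the ring oxygen would extend the rise seen with ethyl.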